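This account rests on a few compounds, and the source may have more. Where it says the series, first, only, none or still open, it means among the compounds named here.

Compound 1 `CC(O)(CSc1ccccc1OC(F)(F)F)C(=O)Nc1cccc(S(F)(F)(F)(F)F)c1`: 10000 nM
Compound 2 `CC(O)(CS(=O)(=O)c1ccc(S(F)(F)(F)(F)F)cc1)C(=O)Nc1ccc(C#N)cc1C(F)(F)F`: 17800 nM
Compound 3 `CC(O)(CS(=O)(=O)c1ccc(S(F)(F)(F)(F)F)cc1)C(=O)Nc1ccc(S(F)(F)(F)(F)F)cc1`: 29200 nM

In a functional assay on LNCaP cells (Homo sapiens) for antiproliferative activity, read by propidium iodide staining, with a stated time of 96 h (on this read-out lower numbers stand for stronger inhibition and higher numbers for weaker inhibition), compound 3 gives 29200 nM. This lies within the scatter of compound 2 at 17800 nM, while the gap to compound 1 at 10000 nM lies beyond the scatter, with compound 3 the weaker of that pair.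

Compound 4 `CC(O)(CS(=O)(=O)c1ccc(C(F)(F)F)cc1)C(=O)Nc1ccc(S(F)(F)(F)(F)F)cc1` has not yet been measured. It keeps the rest of compound 3 and makes a single exchange: a group of 4 heavy atoms (1 carbon, 3 fluorine; no ring) in place of a group of 6 heavy atoms (5 fluorine, 1 sulfur; no ring), on an aromatic carbon. The trifluoromethyl sits on an aromatic carbon, para to a large group.

Among the measured compounds shown here, no two measured compounds differ in one place only, so the data hold no direct precedent for this exchange. For the measured compounds named here, the one loose guide is that compound 2 at 17800 nM and compound 3 at 29200 nM stay within the scatter of each other despite their different groups. No step beyond the scatter is therefore expected in this assay. The expected change, a 1.5-fold lower number from compound 3 to compound 4 (0.16 log units; within the scatter), is small and towards a lower number. Compound 4 is estimated at 20000 nM, with an expected range of 9000 nM to 45000 nM.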

Compound 4, half-maximal inhibitory concentration: 20700 nM
The estimate for compound 4 lay 1.0-fold (0.01 log units) below the measured number; measured number inside the range.
By their numbers in this assay, from the lowest: compounds 1, 2, 4 and 3 (each within the scatter of the next, the first and the last beyond it).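

In this assay, among the compounds shown here, putting trifluoromethyl in place of the group of 6 heavy atoms (5 fluorine, 1 sulfur) on the aromatic carbon gives a 1.4-fold lower number from compound 3 to compound 4 (0.15 log units; within the scatter) and so supplies the first comparison here of compounds that differ in one place only. This step lies within the scatter, so at this position the two groups cannot be told apart in this read-out, and the smaller group leaves the number in the same band as the larger one. Nothing measured here bears on this result.

On these data alone, whether a chlorine atom, a methoxy group or an amine on that same aromatic carbon would also stay within the scatter of compound 3 remains open. As far as these compounds go, it is also open whether the same exchange would give so small a step with the rest of compound 2 kept in place of the rest of compound 3.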